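The source may report more compounds than this note shows. Statements on the series, on what has been measured and on what is new or still open speak of the compounds shown alone.

Compound 3 `CC(C)c1onc(-c2c(Cl)cccc2Cl)c1COc1ccc(N(C)Cc2ccc(C(=O)NS(C)(=O)=O)cc2)c(C(F)(F)F)n1` gives the highest of the three numbers measured in a functional assay on HEK293 cells for agonist activity at Bile acid receptor (Homo sapiens) (on this read-out higher numbers stand for larger maximal responses and lower numbers for smaller maximal responses), with compound 3 reaching 64%. Its nearest neighbour is compound 2 `CC(C)c1onc(-c2c(Cl)cccc2Cl)c1COc1ccc(N(C)Cc2ccc(CCC(=O)O)cc2)c(C(F)(F)F)n1`, which in this assay reaches 55%, a gap that lies within the scatter. Furthest away is compound 1 `CC(C)c1onc(-c2c(Cl)cccc2Cl)c1COc1ccc(N(C)C(=O)c2ccc(C(=O)O)cc2)c(C(F)(F)F)n1`, which in this assay reaches 36%, a gap beyond the scatter. The two known steps are a number 19 percentage points higher from compound 1 to compound 2 (beyond the scatter) and a number 9 percentage points higher from compound 2 to compound 3 (within the scatter).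

Compound 4 `CC(C)c1onc(-c2c(Cl)cccc2Cl)c1COc1ccc(N(C)Cc2ccc(OCC(=O)O)cc2)c(C(F)(F)F)n1` differs from compound 3 in one place: carboxymethoxy in place of (methylsulfonyl)carbamoyl on an aromatic carbon. Among the compounds with values here, the step that bears on this is the one from compound 2 to compound 3, where 2-carboxyethyl gave way to (methylsulfonyl)carbamoyl and the efficacy moved only within the scatter. The change to compound 4 brings back a group of the carboxymethoxy kind, so the expected step in this assay is small, at most a slight drop, estimated as a number 7 percentage points lower from compound 3 to compound 4 (within the scatter). Compound 4 is therefore estimated at 57%, with a range from 42% to 72%.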

Compound 4, largest response reached (reported as efficacy), in percent of the reference or control that the assay uses: 69%
The estimate for compound 4 lay 12 percentage points below the measured number; the measured number falls inside the stated range.
By their numbers in this assay, from the lowest: compound 1; then compounds 2, 3 and 4 (each within the scatter of the next, the first and the last beyond it).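

In this assay, carboxymethoxy in place of (methylsulfonyl)carbamoyl on this aromatic carbon gives a number 5 percentage points higher from compound 3 to compound 4 (within the scatter), so two groups with different atom counts cannot be told apart here. Carboxymethoxy in place of 2-carboxyethyl at the same carbon gives a number 14 percentage points higher from compound 2 to compound 4 (beyond the scatter), the one change at this carbon that clears the scatter, and 4-(carboxymethoxy)benzyl in place of (4-carboxyphenyl)carbonyl on the nitrogen gives a number 33 percentage points higher from compound 1 to compound 4 (beyond the scatter), the largest step among these compounds. No measurement is at hand that would explain these steps.

Still open, on these data alone, is whether a longer chain ending in a carboxylic acid, or an amine, at this carbon would keep the response in this range. Also open, as far as these compounds go, is how far the benzyl link on the nitrogen and the group on the ring each contribute to the largest step.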